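Three Measured Compounds and an Expected Fourth

The compounds below may be only part of what the source reports. "The series", "measured", "known", "first", "only" and "open" are said of these compounds alone.

Three compounds have been measured in a functional assay on CHO cells with adenosine receptor A1 (Homo sapiens) as the target, read by cAMP accumulation and immunoassay, with a stated time of 6 min, tested at 0.01 uM; on this read-out lower numbers stand for a stronger effect and higher numbers for a weaker effect at the one concentration tested:
compound 1 `CC(C)N1CCN(Cc2csc(N)c2C(=O)c2ccc(Cl)cc2)CC1` gives -1%
compound 2 `Nc1scc(CN2CCN(c3ccc(Cl)cc3F)CC2)c1C(=O)c1ccc(Cl)cc1` gives -9.2%
compound 3 `Nc1scc(CN2CCN(c3ccc([N+](=O)[O-])cc3)CC2)c1C(=O)c1ccc(Cl)cc1` gives -12%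

Compound 3 stands lowest of the three; its nearest neighbour is compound 2, with a number 2.8 percentage points lower from compound 2 to compound 3 (within the scatter), while a number 11 percentage points lower from compound 1 to compound 3 (beyond the scatter) lies beyond the scatter. Compound 4 `Nc1scc(CN2CCN(c3ccc(Cl)c(C(F)(F)F)c3)CC2)c1C(=O)c1ccc(Cl)cc1` differs from compound 3 by 4-chloro-3-(trifluoromethyl)phenyl in place of 4-nitrophenyl on an amine nitrogen in a ring. Among the measured compounds shown here, the steps that bear on this change are a number 8.2 percentage points lower from compound 1 to compound 2 (within the scatter), a number 11 percentage points lower from compound 1 to compound 3 (beyond the scatter) and a number 2.8 percentage points lower from compound 2 to compound 3 (within the scatter). Exchanging 4-chloro-2-fluorophenyl for 4-nitrophenyl on the amine nitrogen in the ring gave only a small step, so in this assay no step beyond the scatter is expected from compound 3 to compound 4. The expected step is a number 2 percentage points higher from compound 3 to compound 4 (within the scatter). Compound 4 is therefore estimated at -10%, with a range from -25% to 5%.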

Compound 4, a percentage reported as activity, at one concentration (the size of the read-out at that concentration, not a potency): -2.5%
For compound 4 the middle estimate is 7.5 percentage points below the measured one; the range from low to high includes it.
By their numbers in this assay, from the lowest: compounds 3, 2, 4 and 1 (each within the scatter of the next, the first and the last beyond it).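

In this assay, the 4-chloro-3-(trifluoromethyl)phenyl group gives only steps within the scatter: a number 9.5 percentage points higher from compound 3 to compound 4 (within the scatter), a number 6.7 percentage points higher from compound 2 to compound 4 (within the scatter) and a number 1.5 percentage points lower from compound 1 to compound 4 (within the scatter). Thus, of the three aryl groups at this amine nitrogen, 4-nitrophenyl alone stands beyond the scatter from isopropyl, so aryl groups here do not separate as a set from isopropyl. Nothing available explains these steps.

As far as these compounds go, whether a benzyl group or a longer alkyl chain on this nitrogen would give a larger step remains open. So does how these compounds compare at other concentrations.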